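The source may report more compounds than this note shows. Statements on the series, on what has been measured and on what is new or still open speak of the compounds shown alone.

Measured so far:
Compound 1 `CNC(=O)/C=C/c1ccncc1-c1ccc2cccnc2c1` gives 82% in an assay on a protein complex for inhibition of CDK8/Cyclin C (Homo sapiens), with a stated time of 1 h, tested at 10 uM; a lower number here means less inhibition, a higher number more inhibition at the concentration tested (going by the name of the read-out).
Compound 2 `O=C(/C=C/c1ccncc1-c1ccc2cccnc2c1)N1CCOCC1` gives 33% in this assay.
Compound 3 `O=C(CCc1ccncc1-c1ccc2ccccc2c1)N1CCOCC1` gives 100% in this assay.

Compound 4 `CNC(=O)CCc1ccncc1-c1ccc2ccccc2c1` has not been measured. It arises from compound 3 by one change: methylamino in place of morpholin-4-yl on a carbonyl carbon. The same kind of change links the measured pair, (methylamino in place of morpholin-4-yl on a carbonyl carbon), and there it produced a number 49 percentage points higher from compound 2 to compound 1 (beyond the scatter). The surroundings are not identical, though: in the measured pair the carbonyl carbon's other neighbour is a double-bonded chain carbon, whereas in the new pair it is a saturated chain carbon, so the change is of the same kind, not the same. The cores of compound 2 and compound 3 also differ, and that difference is not broken down here. Compound 4 is expected to show only a number 4 percentage points lower from compound 3 to compound 4 (within the scatter) because compound 3 already gives 100% and the read-out cannot climb further. Compound 4 is estimated at 96%, between 85% and 100%.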

Compound 4, a percentage reported as inhibition, at one concentration (the size of the read-out at that concentration, not a potency): 100%
The estimate for compound 4 lay 4 percentage points below the measured number, and the stated range covers the measured number.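

Methylamino in place of morpholin-4-yl on a carbonyl carbon gives no change at the digits printed from compound 3 to compound 4 (within the scatter) in this assay. Set beside the earlier step, the same change did not carry over at the same size from one core to the other: the same change on two cores in this assay, a number 49 percentage points higher (beyond the scatter) from compound 2 to compound 1 and no change at the digits printed (within the scatter) from compound 3 to compound 4, 49 percentage points apart, beyond the scatter of two such steps

This does not show that the change has no effect on the second core: compound 3 already gives 100%, the top of the scale, so any gain would stay hidden, and the two pairs also differ in their chain and core, which are not separated here.

From the compounds shown here alone, whether compound 3 and compound 4 differ in potency stays open. So does what a dimethylamino or ethylamino group would do in the same place.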